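Thiophen-3-yl for phenyl on the shared nucleoside core

This account rests on a few compounds, and the source may have more. Where it says the series, first, only, none or still open, it means among the compounds named here.

Three measured compounds set the ground. Compound 1 `COc1nc(N)nc2c1c(-c1cc3ccccc3o1)cn2[C@@H]1O[C@H](CO)[C@@H](O)[C@H]1O` gives 15500 nM in a functional assay on K562 cells (Homo sapiens), read by MTT assay, with a stated time of 72 h; a lower number here means a stronger inhibitor, a higher number a weaker inhibitor. Compound 3 `COc1ncnc2c1c(-c1ccccc1)cn2[C@@H]1O[C@H](CO)[C@@H](O)[C@H]1O` reaches only a limit of this assay, > 20000 nM. Compound 2 `Nc1nc2c(c(-c3ccccc3)cn2[C@@H]2O[C@H](CO)[C@@H](O)[C@H]2O)c(=O)[nH]1` likewise stands at a limit in this assay, > 20000 nM, so no number is known for it. Two of the three values shown share (the limit of > 20000 nM in this assay, at which 2 of the 3 values shown sit). Compound 4 `Nc1nc2c(c(-c3ccsc3)cn2[C@@H]2O[C@H](CO)[C@@H](O)[C@H]2O)c(=O)[nH]1` has not been measured; it differs from compound 2 by thiophen-3-yl in place of phenyl on an aromatic carbon. Going by the values given here, no step between measured compounds is available to size this change, so only a small step is expected, in no clear direction and likely within the scatter, as a step that the limit leaves unreadable from compound 2 to compound 4. Compound 4 is therefore expected to give about 25000 nM in this assay, within 8000 nM to 80000 nM.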

Compound 4, half-maximal inhibitory concentration: 18300 nM
Beside the measured number, compound 4's estimate is 1.4-fold (0.14 log units) above it; low and high end bracket the measured number.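

In this assay, thiophen-3-yl in place of phenyl on this aromatic carbon gives a readable number on the shared core, with an at least 1.0-fold lower number from compound 2 to compound 4 (0.03 log units; that floor lies within the scatter). The value of compound 2, > 20000 nM, is a limit and not a number, so only a floor of the step is known, and that floor does not show a real gain for thiophen-3-yl. Much of the reading in this series remains bounded: the limit of > 20000 nM in this assay, at which 2 of the 4 values shown sit.

Open, going by these compounds, is how the true size of this step compares with other changes at this position. Also open, on these data alone, is whether a pyridin-3-yl ring, or an amine carried on the thiophen-3-yl ring, would give a clearly lower number.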